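This account rests on a few compounds, and the source may have more. Where it says the series, first, only, none or still open, it means among the compounds named here.

Measured in a physicochemical assay for lipophilicity; on this read-out higher numbers stand for higher lipophilicity and lower numbers for lower lipophilicity:
- Compound 1 `CC(C)(C)OC(=O)c1ccc(NC(=O)c2cccc(S(N)(=O)=O)c2)cc1`: 1.54
- Compound 2 `NS(=O)(=O)c1cc(C(=O)Nc2ccc(C(F)(F)F)cc2)ccc1Cl`: 2.76
- Compound 3 `NS(=O)(=O)c1cc(C(=O)Nc2ccc([N+](=O)[O-])cc2Cl)ccc1Cl`: 2.73

Compound 2 (2.76) stands level with compound 3, within the scatter, while compound 1 lies lower, beyond the scatter.

Compound 4 `CC(C)(C)OC(=O)c1ccc(NC(=O)c2ccc(Cl)c(S(N)(=O)=O)c2)cc1` has not yet been measured. It has tert-butoxycarbonyl in place of the trifluoromethyl of compound 2, on an aromatic carbon, para to a large group: tert-butoxycarbonyl in place of trifluoromethyl on an aromatic carbon.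

The best guide is compound 1, which carries the same tert-butoxycarbonyl on a slightly different core and gives 1.54. A fall beyond the scatter is therefore expected in this assay, with an estimated step of a number 0.66 log units lower from compound 2 to compound 4 (beyond the scatter). Compound 4 is estimated at 2.1, with an expected range of 1.6 to 2.6.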

Compound 4, partition coefficient: 1.83
For compound 4 the middle estimate is 0.27 log units above the measured one; low and high end bracket the measured number.
By their numbers in this assay, from the lowest: compounds 1 and 4 (each within the scatter of the next); then compounds 3 and 2 (each within the scatter of the next).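

In this assay, tert-butoxycarbonyl in place of trifluoromethyl on this aromatic carbon gives a number 0.93 log units lower from compound 2 to compound 4 (beyond the scatter) on an otherwise unchanged structure, so the larger group by heavy atoms does not bring a higher number. Chloro in place of hydrogen on an aromatic carbon gives a number 0.29 log units higher from compound 1 to compound 4 (within the scatter) here, so this second change cannot be told apart from repeat-measurement noise. Nothing measured here offers a reason for the fall.

On these data alone, how an amine or a carboxylic acid would read at this position remains open. So does whether the fall from trifluoromethyl to tert-butoxycarbonyl holds on the core of compound 1.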